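Amide variation on a shared sulfonamide core: piperazine step

The source may hold more compounds than are shown below. What is called first, only, known or untested is meant among the compounds shown, and "the series" means these compounds.

Measured compounds in an assay on isolated protein for inhibition of alkaline phosphatase, tissue-nonspecific isozyme (Homo sapiens); on this read-out lower numbers stand for stronger inhibition and higher numbers for weaker inhibition:
compound 1, `COc1ccc(Cl)cc1S(=O)(=O)Nc1cncc(C(=O)Nc2ccccc2)c1`, 310 nM
compound 2, `COc1ccc(Cl)cc1S(=O)(=O)Nc1cncc(C(=O)O)c1`, 134 nM
compound 3, `CCNC(=O)c1cncc(NS(=O)(=O)c2cc(Cl)ccc2OC)c1`, 193 nM

Compound 3 gives the second highest of the three numbers in this assay; its nearest neighbour is compound 2 and its furthest is compound 1, both within the scatter. Compound 4, `COc1ccc(Cl)cc1S(=O)(=O)Nc1cncc(C(=O)N2CCN(C)CC2)c1`, carries the change (4-methylpiperazin-1-yl in place of ethylamino on a carbonyl carbon). The bearing steps are all on this carbonyl carbon: a 1.4-fold higher number from compound 2 to compound 3 (0.16 log units; within the scatter), a 1.6-fold lower number from compound 1 to compound 3 (0.21 log units; within the scatter) and a 2.3-fold lower number from compound 1 to compound 2 (0.36 log units; beyond the scatter). Changes here have moved the number little, so for compound 4 a step of a 1.3-fold higher number from compound 3 to compound 4 (0.11 log units; within the scatter) is expected, not beyond the scatter. Compound 4 is estimated at 250 nM, between 100 nM and 650 nM.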

Compound 4, half-maximal inhibitory concentration: 671 nM
Beside the measured number, compound 4's estimate is 2.7-fold (0.43 log units) below it, and the stated range ends below it.
By their numbers in this assay, from the lowest: compounds 2, 3 and 1 (each within the scatter of the next, the first and the last beyond it); then compound 4.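

In this assay, among the compounds shown here, 4-methylpiperazin-1-yl is the first group on this carbonyl carbon to set its compound apart from all the others, with a 3.5-fold higher number from compound 3 to compound 4 (0.54 log units; beyond the scatter) and a 5.0-fold higher number from compound 2 to compound 4 (0.70 log units; beyond the scatter) and a 2.2-fold higher number from compound 1 to compound 4 (0.34 log units; beyond the scatter) as its steps. Compound 4 is thus the weakest of the four, showing that this position does not accept every amide alike. Nothing available accounts for this loss. The change brings in a ring and a second nitrogen and removes the amide hydrogen all at once, and the compounds shown do not separate these. Dimethylamino or morpholin-4-yl on this carbonyl carbon remains an open comparison.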